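A few compounds are considered here, and "the series" means these few. Any claim that something is new, unique, unknown or untested is made for them only; others in the source may bear on it.

Compound 2 `CCS(=O)(=O)NC(=O)c1ccc(Nc2nc(NC3(c4ccc(Cl)cc4)CC3)nc(OCC(F)(F)F)n2)cc1`: 28 nm/s
Compound 1 `CC(C)(C)OC(=O)NCCS(=O)(=O)NC(=O)c1ccc(Nc2nc(NC3(c4ccc(Cl)cc4)CC3)nc(OCC(F)(F)F)n2)cc1`: 111 nm/s
Compound 3 `CC(C)(C)CNCCS(=O)(=O)NC(=O)c1ccc(Nc2nc(NC3(c4ccc(Cl)cc4)CC3)nc(OCC(F)(F)F)n2)cc1`: 651 nm/s

In a physicochemical assay for permeability, using PAMPA, at pH 7.4 (on this read-out lower numbers stand for lower permeability and higher numbers for higher permeability), compound 2 gives the lowest of the three numbers; both other compounds sit higher, beyond the scatter: a 4.0-fold lower number from compound 1 to compound 2 (0.60 log units; beyond the scatter), and a 23-fold higher number from compound 2 to compound 3 (1.37 log units; beyond the scatter).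

Compound 4 `O=C(NS(=O)(=O)CCNCc1ccccc1)c1ccc(Nc2nc(NC3(c4ccc(Cl)cc4)CC3)nc(OCC(F)(F)F)n2)cc1` is the next step from compound 2: benzylamino in place of hydrogen on a saturated chain carbon, two bonds along the chain from a sulfonyl sulfur. Within the data shown here, the step that bears on it most directly is the one to compound 3, where an alkyl-bearing amine entered at the same place, which carried a 23-fold higher number from compound 2 to compound 3 (1.37 log units; beyond the scatter). The step from compound 1 to compound 3, a 5.9-fold higher number from compound 1 to compound 3 (0.77 log units; beyond the scatter), points the same way. A large rise in this assay is therefore expected for compound 4, a 14-fold higher number from compound 2 to compound 4 (1.15 log units; beyond the scatter). Compound 4 is estimated at 400 nm/s, with a range from 150 nm/s to 1000 nm/s.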

Compound 4, apparent permeability: 49 nm/s
Estimate against measurement, compound 4: 8.2-fold (0.91 log units) above; measured number below the stated range.
By their numbers in this assay, from the lowest: compounds 2 and 4 (each within the scatter of the next); then compound 1; then compound 3.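

In this assay, an amine at this chain carbon does not by itself set a compound apart from compound 2, since benzylamino gives a 1.8-fold higher number from compound 2 to compound 4 (0.24 log units; within the scatter). What sits on the amine nitrogen matters here: phenyl in place of tert-butyl gives a 13-fold lower number from compound 3 to compound 4 (1.12 log units; beyond the scatter), and benzyl in place of tert-butoxycarbonyl gives a 2.3-fold lower number from compound 1 to compound 4 (0.36 log units; beyond the scatter). No supporting data bear on what lies behind these steps.

Open, on these data alone, is whether neopentyl stands alone or other saturated groups on that nitrogen, such as cyclohexylmethyl, behave alike. Also open, as far as these compounds go, is how phenethyl, with its longer chain to the ring, compares with benzyl.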